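Changing the Group on the Amide Nitrogen of Compound 1

This account rests on a few compounds, and the source may have more. Where it says the series, first, only, none or still open, it means among the compounds named here.

Measured compounds:
compound 1 `COc1nsc(NC(=O)C(=O)c2cn(C(C)C)c3ccccc23)n1`: 10400 nM
compound 2 `COC(=O)CCn1cc(C(=O)C(=O)Nc2ccc(OC)nc2)c2ccccc21`: 168 nM
compound 3 `COCCc1cc(C(=O)C(=O)Nc2ccc(OC)nc2)c2ccccn12`: 36 nM

In a functional assay on FaDu cells (Homo sapiens) for cytotoxicity, read by MTT assay, with a stated time of 72 h (a higher number here means that more compound is tolerated, a lower number that less compound is tolerated), compound 1 gives 10400 nM, the highest of the three numbers. Compound 2 gives 168 nM and compound 3 gives 36 nM; both gaps to compound 1 lie well beyond the usual scatter, so compound 1 is the one tolerated at the highest concentration. Compound 4 `COc1ccc(NC(=O)C(=O)c2cn(C(C)C)c3ccccc23)cc1` keeps the core of compound 1 and differs from it in one place: 4-methoxyphenyl in place of 3-methoxy-1,2,4-thiadiazol-5-yl on an amide-type nitrogen. Among the measured compounds shown here, compounds 2 and 3 differ from compound 1 in more than one place, so no measured pair isolates this change. What the numbers do show is that the two compounds bearing a different group on the amide-type nitrogen give far lower values than compound 1. On that basis the step of an 8.7-fold lower number from compound 1 to compound 4 (0.94 log units; beyond the scatter) is expected to lower the number beyond the scatter, while stopping short of the levels of compounds 2 and 3. Compound 4 is estimated at 1200 nM, with a likely range from 250 nM to 6000 nM.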

Compound 4, concentration lethal to 50% of the cells: 181 nM
Beside the measured number, compound 4's estimate is 6.6-fold (0.82 log units) above it; measured number below the stated range.
By their numbers in this assay, from the lowest: compound 3; then compounds 2 and 4 (each within the scatter of the next); then compound 1.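

With the rest of compound 1 unchanged, placing 4-methoxyphenyl in place of 3-methoxy-1,2,4-thiadiazol-5-yl on the amide-type nitrogen gives a 57-fold lower number from compound 1 to compound 4 (1.76 log units; beyond the scatter) in this assay. This single-place comparison shows that the group on this nitrogen can by itself shift the measured lethal concentration by a large margin, although the swap alters several features at once: a five-membered aromatic ring with hetero atoms gives way to a six-membered ring of carbon only. No measurement shown here gives a reason for the drop. The compounds shown leave open what a plain phenyl or a 4-aminophenyl group would give on this nitrogen, and therefore what part the methoxy group plays. They also leave open whether the same swap would produce a similar step on a different core.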